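Lengthening the Amide Chain by One Carbon

A few compounds are considered here, and "the series" means these few. Any claim that something is new, unique, unknown or untested is made for them only; others in the source may bear on it.

Compound 3 `CCCCCNC(=O)CC1CCc2cc(OC)c(OC)cc21` gives the highest value of the three in a functional assay on the whole organism (strain Wistar) for inhibition, with Rattus norvegicus as the target, read by paw edema, with stated times of 60 min and 24 h, at a dose of 100 mg/kg by the oral route (on this read-out lower numbers stand for less inhibition and higher numbers for more inhibition at the one dose given (going by the name of the read-out)), at 46.7%. In this assay compound 1 `CCN(CC)C(=O)CC1CCc2cc(OC)c(OC)cc21` gives 16.7%, and compound 2 `COc1cc2c(cc1OC)C(CC(=O)NC(C)C)CC2` gives 30%. Compound 4 `CCCCCCNC(=O)CC1CCc2cc(OC)c(OC)cc21` differs from compound 3 by methyl in place of hydrogen on a saturated chain carbon, five bonds along the chain from an amide-type nitrogen. Among the compounds with values here, the steps that bear on this change all alter the group on the amide nitrogen: a number 30 percentage points higher from compound 1 to compound 3 (beyond the scatter) and a number 16.7 percentage points higher from compound 2 to compound 3 (beyond the scatter), both modest rises as that group grew, while a number 13.3 percentage points higher from compound 1 to compound 2 (beyond the scatter) was smaller. On this basis one more chain carbon is expected to bring a further rise, though a smaller one that may fall within the scatter. Compound 4 is expected to give 52%, between 35% and 70%, a step of a number 5.3 percentage points higher from compound 3 to compound 4 (within the scatter).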

Compound 4, a percentage reported as inhibition, in the whole organism at one dose (the size of the read-out at that dose, not a potency): 45.5%
Compound 4: middle estimate off by 6.5 percentage points, on the high side; the range from low to high includes it.
By their numbers in this assay, from the lowest: compound 1; then compound 2; then compounds 4 and 3 (each within the scatter of the next).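

In this assay the methyl on a saturated chain carbon, five bonds along the chain from an amide-type nitrogen, gives (a number 1.2 percentage points lower from compound 3 to compound 4 (within the scatter)), so the pentyl and hexyl amides cannot be told apart. The hexyl amide keeps the advantage over the two branched amides, with (a number 15.5 percentage points higher from compound 2 to compound 4 (beyond the scatter)) and (a number 28.8 percentage points higher from compound 1 to compound 4 (beyond the scatter)). No evidence here bears on why this extra carbon makes no clear difference.

As far as these compounds go, whether a longer chain such as heptyl would hold this level remains open. So does the effect of an amine or a carboxylic acid at the chain end.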